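This account rests on a few compounds, and the source may have more. Where it says the series, first, only, none or still open, it means among the compounds named here.

Going by the values given here, in a functional assay on T47D cells (Homo sapiens) for inhibition, read by sulforhodamine B assay, with a stated time of 48 h (on this read-out lower numbers stand for stronger inhibition of growth and higher numbers for weaker inhibition of growth), compound 2 `O=C(Cc1csc2nc(-c3ccc(Br)cc3)cn12)N/N=C/c1ccc(O)cc1` gives 31600 nM, the higher of the two numbers so far, while compound 1 `O=C(Cc1csc2nc(-c3ccc(Br)cc3)cn12)N/N=C/c1ccccc1O` gives 5250 nM. The next compound, compound 3 `COc1cccc(OC)c1/C=N/NC(=O)Cc1csc2nc(-c3ccc(Br)cc3)cn12`, differs from compound 2 in one group: 2,6-dimethoxyphenyl in place of 4-hydroxyphenyl on a carbon with a double bond to nitrogen. Among the compounds with values here, only one measured step bears on this change, a 6.0-fold higher number from compound 1 to compound 2 (0.78 log units; beyond the scatter), which is modest and shows that the group on this carbon can shift the number. Compound 3 lacks the 4-hydroxyphenyl of compound 2, so a modest move to a lower number is expected. The estimated change is a 2.3-fold lower number from compound 2 to compound 3 (0.35 log units; beyond the scatter). For compound 3 the estimate is 14000 nM, with an expected range from 4500 nM to 35000 nM.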

Compound 3, concentration for 50% growth inhibition: 40700 nM
Compound 3: the middle estimate sits 2.9-fold (0.46 log units) below what was measured, outside the stated range (above it).
By their numbers in this assay, from the lowest: compound 1; then compounds 2 and 3 (each within the scatter of the next).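

In this assay the swap of 4-hydroxyphenyl for 2,6-dimethoxyphenyl gives a 1.3-fold higher number from compound 2 to compound 3 (0.11 log units; within the scatter) and so does not separate the two compounds. The swap of 2-hydroxyphenyl for 2,6-dimethoxyphenyl gives a 7.8-fold higher number from compound 1 to compound 3 (0.89 log units; beyond the scatter) and so, of the three groups on this carbon, only the 2-hydroxyphenyl of compound 1 stands apart, with the lowest number. No measurement shown here explains this difference. As far as these compounds go, it remains open whether other groups on this carbon, such as an aminophenyl or a carboxylic acid on the phenyl ring, would reach the number of compound 1 or go lower.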